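This account rests on a few compounds, and the source may have more. Where it says the series, first, only, none or still open, it means among the compounds named here.

Working notes on the series. In a functional assay on U-937 cells (Homo sapiens) for antiproliferative activity, with a stated time of 48 h (on this read-out lower numbers stand for an effect already at smaller amounts and higher numbers for an effect only at larger amounts of compound), compound 1 (`O=C(CCCCCCC(=O)Nc1ccc(C(F)(F)F)cc1)NO`) gives 450 nM and compound 2 (`O=C(CCCCCCC(=O)Nc1cccc(Cl)c1)NO`) gives 350 nM on the same read-out. These two numbers lie within the scatter of each other, so compound 1 stands level with the only other measured point. Next is compound 3 (`O=C(CCCCCCC(=O)Nc1ccc([N+](=O)[O-])cc1)NO`), which has nitro in place of trifluoromethyl on an aromatic carbon, para to a large group (nitro in place of trifluoromethyl on an aromatic carbon). Going by the values given here, no measured pair isolates this exchange, so the data give no direct guide to it. In this assay no clear direction is expected: the estimated step of a 1.1-fold lower number from compound 1 to compound 3 (0.05 log units; within the scatter) is not expected to go beyond the scatter. The estimate therefore rests on compound 1 at 450 nM and on the shared core. For compound 3 the estimated value is 400 nM with an expected range from 150 nM to 1000 nM in this series.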

Compound 3, half-maximal effective concentration: 22000 nM
Beside the measured number, compound 3's estimate is 55-fold (1.74 log units) below it; measured number above the stated range.
By their numbers in this assay, from the lowest: compounds 2 and 1 (each within the scatter of the next); then compound 3.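

In this assay, nitro in place of trifluoromethyl on an aromatic carbon, para to a large group, gives a 49-fold higher number from compound 1 to compound 3 (1.69 log units; beyond the scatter), a large step that shows this place is not indifferent to the group it carries. Going by these compounds alone, this is the first measured pair to isolate a single exchange, and it shows that two small groups, neither with a ring nor a hydrogen-bond donor, can lie far apart on this read-out. No measured data shown here bear on what lies behind the step.

From the compounds shown here alone, it remains open whether an amine, a nitrile or a carboxylic acid at this place would give a number close to that of compound 1 or of compound 3. Going by these compounds, it is also open whether the same exchange would give a step of this size on a longer chain.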